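Chloro on the Phenyl of Compound 1: an Expected Step

A few compounds are considered here, and "the series" means these few. Any claim that something is new, unique, unknown or untested is made for them only; others in the source may bear on it.

Compound 1 `CC1=CC[C@@H]([C@@](C)(O)CCCC(C)(C)NC(=S)N/N=C\c2ccccc2)CC1` is the reference point of this small set. In a functional assay on K562 cells (Homo sapiens) for cytotoxicity, read by sulforhodamine B assay (on this read-out lower numbers stand for stronger inhibition of growth and higher numbers for weaker inhibition of growth), compound 1 gives 130 nM, the lowest of the three measured numbers. Compound 2 `CC1=CC[C@@H]([C@@](C)(O)CCCC(C)(C)NC(=S)N/N=C\c2ccccc2[N+](=O)[O-])CC1` gives 190 nM in this assay, and the step of a 1.5-fold higher number from compound 1 to compound 2 (0.16 log units; within the scatter) lies within the scatter. Compound 3 `CC1=CC[C@@H]([C@@](C)(O)CCCC(C)(C)NC(=S)N/N=C\c2ccc([N+](=O)[O-])cc2)CC1` gives 4220 nM; the step of a 32-fold higher number from compound 1 to compound 3 (1.51 log units; beyond the scatter) is large, and the step of a 22-fold higher number from compound 2 to compound 3 (1.35 log units; beyond the scatter) shows the same gap from the other side.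

Compound 4 `CC1=CC[C@@H]([C@@](C)(O)CCCC(C)(C)NC(=S)N/N=C\c2ccc(Cl)cc2)CC1` has not yet been measured. It differs from compound 1 by chloro in place of hydrogen on an aromatic carbon, on an aromatic carbon para to a large group. Among the compounds with values here, the only measured step at this place, a 32-fold higher number from compound 1 to compound 3 (1.51 log units; beyond the scatter), put a nitro group there and gave a large rise, while the step of a 1.5-fold higher number from compound 1 to compound 2 (0.16 log units; within the scatter) placed nitro elsewhere and stayed within the scatter. Chloro is not nitro, and no chloro compound has been measured here, so the expectation is a rise smaller than that seen for compound 3 but beyond the scatter. Compound 4 is estimated at 500 nM, with a range from 150 nM to 2500 nM. The expected step is a 3.8-fold higher number from compound 1 to compound 4 (0.59 log units; beyond the scatter).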

Compound 4, concentration for 50% growth inhibition: 40 nM
Compound 4: middle estimate off by 13-fold (1.10 log units), on the high side, outside the stated range (below it).
By their numbers in this assay, from the lowest: compound 4; then compounds 1 and 2 (each within the scatter of the next); then compound 3.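

In this assay, the place para to a large group on the aromatic ring does not raise the number with every group: chloro there gives a 3.3-fold lower number from compound 1 to compound 4 (0.51 log units; beyond the scatter) and so goes the opposite way to nitro at the same place. Exchanging one group for the other at this place gives a 110-fold lower number from compound 3 to compound 4 (2.02 log units; beyond the scatter) and shows that, among these compounds, the identity of the group there matters greatly. The step of a 4.8-fold lower number from compound 2 to compound 4 (0.68 log units; beyond the scatter) is also beyond the scatter, which leaves the 4-chlorophenyl compound with the lowest number of the four.

As far as these compounds go, whether a methoxy group, an amine or fluoro at this place would follow chloro or nitro remains open, as does the effect of chloro at the place of the nitro in compound 2. Nothing measured here bears on why chloro and nitro part so widely.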